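From 2-chlorophenyl to 2,4-difluorophenyl at an assay limit

The compounds below may be only part of what the source reports. "The series", "measured", "known", "first", "only" and "open" are said of these compounds alone.

Of the compounds shown here, three sharing one core have been tested in an ADME assay on microsomes from liver (Canis lupus familiaris) for metabolic stability; on this read-out lower numbers stand for a shorter-lived compound and higher numbers for a longer-lived compound: compound 1 `N#Cc1ccc(-c2nc(NCCNc3ccc([N+](=O)[O-])c(N)n3)ncc2-c2ncc[nH]2)cc1`, compound 2 `Nc1nc(NCCNc2ncc(-c3ncc[nH]3)c(-c3ccc(C(F)(F)F)cc3)n2)ccc1[N+](=O)[O-]` and compound 3 `Nc1nc(NCCNc2ncc(-c3ncc[nH]3)c(-c3ccccc3Cl)n2)ccc1[N+](=O)[O-]`. Compound 1 gives > 0.5 h, which is a limit of the assay and not a number. Compound 2 gives > 0.5 h, also a limit. Compound 3 likewise stands only at a limit, > 0.5 h. Among the compounds with values here, the whole series so far therefore comes down to the limit of > 0.5 h in this assay, at which 3 of the 3 values shown sit.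

The next compound is compound 4 `Nc1nc(NCCNc2ncc(-c3ncc[nH]3)c(-c3ccc(F)cc3F)n2)ccc1[N+](=O)[O-]`, which has not yet been measured. It carries 2,4-difluorophenyl in place of 2-chlorophenyl on an aromatic carbon. Two measured changes of the group at this place bear on it: a step that the two limits leave unreadable from compound 1 to compound 3 and a step that the two limits leave unreadable from compound 2 to compound 3. Neither has a readable size, so neither gives a direction. The third measured change, a step that the two limits leave unreadable from compound 1 to compound 2, is equally unreadable.

With no readable step to draw on, and with compound 3 at the limit of > 0.5 h, no step beyond the scatter is expected in this assay, in either direction. The estimated change is a step that the limit leaves unreadable from compound 3 to compound 4. Compound 4 will most likely be reported as a limit again. As a number, compound 4 is estimated at 0.8 h, with an expected range from 0.4 h to 2 h.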

Compound 4, half-life: > 0.5 h
Compound 4 was reported as a limit (the forecaster's own chance of this, stated with the estimate: 85%); the middle value does not contradict the limit.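

No step from compound 1, compound 2 or compound 3 to compound 4 can be read in this assay, and the steps among the first three remain equally unreadable: the limit of > 0.5 h in this assay, at which 4 of the 4 values shown sit.

The compounds shown leave open what half-life any of the four has as a number, and whether the groups exchanged at this place differ at all in this assay.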